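This account rests on a few compounds, and the source may have more. Where it says the series, first, only, none or still open, it means among the compounds named here.

Three compounds built on one shared core were run in an ADME assay on microsomes from liver (Homo sapiens) for pharmacokinetics; on this read-out higher numbers stand for fast clearance and lower numbers for slow clearance. Compound 1 `Cc1nn(CC2(O)COC2)cc1Nc1nc(N)c2c(C#N)c(N3CCC[C@H]3C)n(C)c2n1` gives 76.7 mL/min/kg in this assay. Compound 2 `Cc1c(Nc2nc(N)c3c(C#N)c(N4CCC[C@H]4C)n(C)c3n2)cnn1[C@@H]1CCOC1` gives 28.3 mL/min/kg in this assay, and compound 3 `C[C@@H]1CCCN1c1c(C#N)c2c(N)nc(Nc3cn(C)nc3C(F)(F)F)nc2n1C` gives 33.3 mL/min/kg in this assay. On these numbers compound 2 and compound 3 lie within the usual scatter of each other, so no order can be read between them, whereas the gap from compound 2 to compound 1 is beyond the scatter, with compound 1 showing the faster clearance.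

Compound 4 `Cc1c(Nc2nc(N)c3c(C#N)c(N4CCC[C@H]4C)n(C)c3n2)cnn1CC1(O)COC1` has not yet been measured. It differs from compound 2 at a single place: (3-hydroxyoxetan-3-yl)methyl in place of oxolan-3-yl on an aromatic nitrogen. For the measured compounds named here, the group that enters is the one carried by compound 1, while the rest of compound 4 matches compound 2.

Going by the values given here, no measured pair isolates this change, so the expectation rests on the neighbours. An upward step is expected because compound 1 with the same entering group gives 76.7 mL/min/kg in this assay, though compound 1 also differs from compound 4 elsewhere, so the full gap need not carry over. The step of a 1.8-fold higher number from compound 2 to compound 4 (0.25 log units; within the scatter) is expected to be moderate, beyond the scatter yet short of the number for compound 1. Compound 4 is therefore expected to give 50 mL/min/kg in this assay, with a range from 28 mL/min/kg to 90 mL/min/kg.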

Compound 4, clearance: 35 mL/min/kg
Beside the measured number, compound 4's estimate is 1.4-fold (0.15 log units) above it; low and high end bracket the measured number.
By their numbers in this assay, from the lowest: compounds 2, 3 and 4 (each within the scatter of the next); then compound 1.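

For the compounds shown here, this pair gives the first direct reading of the aromatic nitrogen next to the ring atom that bears a methyl group: in this assay, putting (3-hydroxyoxetan-3-yl)methyl in place of oxolan-3-yl gives a 1.2-fold higher number from compound 2 to compound 4 (0.09 log units; within the scatter), so the two compounds cannot be told apart. At this place, the read-out therefore does not separate a five-membered non-aromatic ring with a defined stereocentre and no hydrogen-bond donor from a four-membered non-aromatic ring in a group that has a hydrogen-bond donor and no defined stereocentre. The data shown offer no measurement that would explain this result.

Going by these compounds alone, with only this one pair at the position, it remains open whether the same holds for groups of another kind on this nitrogen, such as an amine or a carboxylic acid. From the compounds shown here alone, it also remains open whether this pair would read the same way on a compound with a different group elsewhere on the shared core, or in any read-out other than this assay.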